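This account rests on a few compounds, and the source may have more. Where it says the series, first, only, none or still open, it means among the compounds named here.

Going by the values given here, compound 2 `Nc1cc(N)c2nc(-c3ccccc3)c(Sc3ccc(Cl)c(Cl)c3)nc2c1` gives 60300 nM in a functional assay on SF-295 cells (Homo sapiens) for inhibition, read by sulforhodamine B assay, with a stated time of 48 h (on this read-out higher numbers stand for weaker inhibition of growth and lower numbers for stronger inhibition of growth), the higher of the two numbers so far; compound 1 `Nc1cc(N)c2nc(-c3ccccc3)c(NCc3ccc(F)cc3)nc2c1` gives 13500 nM. Among the compounds with values here, the one step, a 4.5-fold higher number from compound 1 to compound 2 (0.65 log units; beyond the scatter), changes the linker and the aryl group together. Compound 3 `Nc1cc(N)c2nc(-c3ccccc3)c(Sc3ccc(F)cc3)nc2c1` differs from compound 2 by 4-fluorophenyl in place of 3,4-dichlorophenyl on a sulfur, keeping the sulfur linker. Within the data shown here, no step isolates the aryl group on sulfur, so the direction is uncertain; compound 3 is expected to lie near compound 2, at 40000 nM (range 13000 nM to 120000 nM), a step of a 1.5-fold lower number from compound 2 to compound 3 (0.18 log units; within the scatter).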

Compound 3, concentration for total growth inhibition: 30200 nM
Compound 3: middle estimate off by 1.3-fold (0.12 log units), on the high side; low and high end bracket the measured number.
By their numbers in this assay, from the lowest: compound 1; then compounds 3 and 2 (each within the scatter of the next).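

On the sulfur, 3,4-dichlorophenyl and 4-fluorophenyl cannot be told apart in this assay (a step of a 2.0-fold lower number from compound 2 to compound 3 (0.30 log units; within the scatter)). With the 4-fluoro substituent now kept on both sides, (4-fluorophenyl)sulfanyl in place of (4-fluorobenzyl)amino still gives a modest step beyond the scatter (a 2.2-fold higher number from compound 1 to compound 3 (0.35 log units; beyond the scatter)), so both sulfanyl compounds give higher numbers than compound 1. No measurement at hand explains either step.

Still open, from the compounds shown here alone, is whether that step follows the sulfur or the loss of the benzyl carbon. A benzylsulfanyl or phenylamino group on this aromatic carbon would separate the two.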